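Adding a Dimethylaminophenyl Group Where Every Value Is a Limit

The source may report more compounds than this note shows. Statements on the series, on what has been measured and on what is new or still open speak of the compounds shown alone.

Compound 3 `CCOC(=O)CCCCCOc1cccc(CN(C(=O)c2ccccc2)C(C)C)c1`, compound 2 `CC(C)N(Cc1cccc(OCCCCCC(=O)O)c1)C(=O)c1ccccc1` and compound 1 `CC(C)N(Cc1cccc(OCCCCCC(=O)O)c1)C(=O)c1ccc(-c2cccc(N(C)C)c2)cc1` were tested in an ADME assay on Raji cells (Homo sapiens) for cytotoxicity, read by CellTiter-Glo and resazurin assay, with a stated time of 72 h; a higher number here means that more compound is needed for the effect, a lower number that less compound is needed. In this assay compound 3 reaches only the limit > 26000 nM, which is not a number. Compound 2 likewise sits at the limit > 26000 nM. Compound 1 also gives the limit > 26000 nM. Because (the limit of > 26000 nM in this assay, at which 3 of the 3 values shown sit), neither a step that the two limits leave unreadable from compound 1 to compound 2 nor a step that the two limits leave unreadable from compound 2 to compound 3 has a readable size. Compound 4 `CCOC(=O)CCCCCOc1cccc(CN(C(=O)c2ccc(-c3cccc(N(C)C)c3)cc2)C(C)C)c1` differs from compound 3 by 3-(dimethylamino)phenyl in place of hydrogen on an aromatic carbon. The same change, in the opposite direction, separates compound 1 from compound 2, and its size stays unreadable. With no readable step to lean on, compound 4 is expected to remain near the limit, so the estimated step that the limit leaves unreadable from compound 3 to compound 4 is small. Compound 4 is therefore estimated at 30000 nM, within 10000 nM to 100000 nM.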

Compound 4, half-maximal effective concentration: > 26000 nM
Compound 4: no number, only a limit; the forecaster's own chance of this, stated with the estimate: 80%; the middle value does not contradict the limit.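

Compound 4 ends at a limit, as do compound 1 and compound 3, so neither of its steps can be read: the limit of > 26000 nM in this assay, at which 4 of the 4 values shown sit. The compounds shown leave open whether adding 3-(dimethylamino)phenyl or ethyl changes the amount needed in this assay.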